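The source may report more compounds than this note shows. Statements on the series, on what has been measured and on what is new or still open speak of the compounds shown alone.

Compound 1 `CNc1nc(NC)nc(NC2(C#N)CCCCC2)n1` and compound 2 `CNc1nc(NC2(C#N)CCCCC2)nc(N(C)C)n1` share one core. In an in vitro assay on Sf21 cells for inhibition of high affinity 3',5'-cyclic-AMP phosphodiesterase 7A (Homo sapiens) (on this read-out higher numbers stand for weaker inhibition and lower numbers for stronger inhibition), compound 1 gives > 1000 nM, which is a limit of the assay and not a number. In this assay compound 2 gives > 5000 nM, again a limit rather than a number. The step that the two limits leave unreadable from compound 1 to compound 2 therefore cannot be read, as both the limit of > 1000 nM in this assay, at which 1 of the 2 values shown sits, and the limit of > 5000 nM in this assay, at which 1 of the 2 values shown sits, are limits. Within the data shown here, compound 2 stands only at a limit in this assay, and the one other value shown is a limit too. Compound 3 `CNc1nc(NC2(C#N)CCCCC2)nc(N2CCCC2)n1` differs from compound 2 by pyrrolidin-1-yl in place of dimethylamino on an aromatic carbon. Among the measured compounds shown here, no measured step bears on this change, and the only measured step that the two limits leave unreadable from compound 1 to compound 2 is itself unreadable, so the measurements give no direction or size to expect. With compound 2 at a limit, compound 3 is expected to remain weak, the step that the limit leaves unreadable from compound 2 to compound 3 being an estimate only. Compound 3 is thus estimated at 10000 nM, within 3000 nM to 40000 nM.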

Compound 3, half-maximal inhibitory concentration: > 5000 nM
Compound 3 was reported as a limit; the forecaster's own chance of this, stated with the estimate: 85%; the middle value is on the limit's open side.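

In this assay compound 3 gives > 5000 nM, a limit of the assay and not a number. The steps to compound 3 from compound 1 and from compound 2 cannot be read. The compounds shown leave open how pyrrolidin-1-yl compares with dimethylamino or methylamino on the shared core.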